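The source may hold more compounds than are shown below. What is called first, only, known or untested is meant among the compounds shown, and "the series" means these compounds.

Three compounds have been measured so far:

Compound 1, `CN(C(=O)NC(=O)c1ccc(Cl)cc1Cl)c1nc(C(F)(F)F)c(C(=O)N/N=C/c2cccc(C(F)(F)F)c2)s1`: 6.11 ug/mL
Compound 2, `Cc1nc(N(C)C(=O)NC(=O)c2c(F)cccc2F)sc1C(=O)N/N=C/c1cccc(C(F)(F)F)c1`: 32.7 ug/mL
Compound 3, `CN(C(=O)NC(=O)c1ccc(Cl)cc1Cl)c1nc(C(F)(F)F)c(C(=O)N/N=C/c2ccccc2C(F)(F)F)s1`: 5.73 ug/mL

These numbers come from a functional assay on BCG823 cells (Homo sapiens) for inhibition, read by MTT assay, with a stated time of 72 h; a higher number here means a weaker inhibitor, a lower number a stronger inhibitor. Compound 1 and compound 3 share one core; compound 2 is built on a different core, and the difference between the two cores is not broken down here. In this assay compound 2 gives the highest number of the three, and its distance from both compound 1 and compound 3 lies beyond the usual scatter.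

The change from compound 1 to compound 3 is 2-(trifluoromethyl)phenyl in place of 3-(trifluoromethyl)phenyl on a carbon with a double bond to nitrogen. It made a step of a 1.1-fold lower number from compound 1 to compound 3 (0.03 log units; within the scatter), which is within the scatter.

Compound 4, `Cc1nc(N(C)C(=O)NC(=O)c2c(F)cccc2F)sc1C(=O)N/N=C/c1ccccc1C(F)(F)F`, has not yet been measured in this assay. It differs from compound 2 by 2-(trifluoromethyl)phenyl in place of 3-(trifluoromethyl)phenyl on a carbon with a double bond to nitrogen. The surroundings of the place are described in the same words for both pairs, so this is the same change applied to the core of compound 2.

Because the same change gave a 1.1-fold lower number from compound 1 to compound 3 (0.03 log units; within the scatter) from compound 1 to compound 3, a step of about that size is expected from compound 2 to compound 4, namely a 1.1-fold lower number from compound 2 to compound 4 (0.02 log units; within the scatter). That expectation rests on a single measured pair, so it is held loosely. Compound 4 is estimated at 31 ug/mL, with a likely range from 16 ug/mL to 60 ug/mL.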

Compound 4, half-maximal inhibitory concentration: 7.88 ug/mL
Compound 4: middle estimate off by 3.9-fold (0.59 log units), on the high side; measured number outside the range, below it.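

In this assay, putting 2-(trifluoromethyl)phenyl in place of 3-(trifluoromethyl)phenyl gave a 4.1-fold lower number from compound 2 to compound 4 (0.62 log units; beyond the scatter), a clear gain in strength on the core of compound 2. The change therefore did not carry over at the same size from one core to the other: the same change on two cores in this assay, a 1.1-fold lower number (0.03 log units; within the scatter) from compound 1 to compound 3 and a 4.1-fold lower number (0.62 log units; beyond the scatter) from compound 2 to compound 4, 3.9-fold (0.59 log units) apart, beyond the scatter of two such steps. Within the data shown here, this shows that, for these two pairs, the effect of the swap depends on the core it sits on, so a step measured on one core is a poor guide to the other; with only one pair per core, however, it does not show which part of the difference between the cores matters, nor why.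

The compounds shown leave open how a plain phenyl, or a phenyl carrying an amine or a carboxylic acid in place of trifluoromethyl, would behave at this place. They also leave open how large the step would be on a third core.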